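A few compounds are considered here, and "the series" means these few. Any claim that something is new, unique, unknown or untested is made for them only; others in the source may bear on it.

Measured in a functional assay on DU-145 cells (Homo sapiens) for cytotoxicity, read by sulforhodamine B assay, with a stated time of 3 days; a lower number here means that less compound is needed, a higher number that more compound is needed for the effect:
compound 1 `Cc1coc(-c2ccc3c(c2O)CCCC3)c1C(=O)O`: 40.4 uM
compound 2 `COc1c(-c2occ(C)c2C(=O)O)ccc2c1CCCC2(C)C`: 34.1 uM
compound 3 `CCc1cccc2c(O)c(-c3occ(C)c3C(=O)O)ccc12`: 29.4 uM

Compound 2 lies within the scatter of both compound 1 and compound 3, so the three values form a single group and no order can be read from them. The next compound to be tested is compound 4 `COc1c(-c2occ(C)c2CO)ccc2c1CCCC2(C)C`, which keeps the core of compound 2 but has hydroxymethyl in place of carboxy on an aromatic carbon. Going by the values given here, all three measured compounds carry carboxy, so the series holds no measured example of this change and any expectation rests on little. The starting point is compound 2 at 34.1 uM. A modest move towards less compound needed is expected, and it may not clear the scatter by much: the estimated change is a 1.7-fold lower number from compound 2 to compound 4 (0.23 log units; within the scatter). The estimated value for compound 4 is 20 uM, with an expected range of 7 uM to 55 uM.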

Compound 4, concentration for half-maximal effect: 21.7 uM
Estimate against measurement, compound 4: 1.1-fold (0.04 log units) below; the measured number falls inside the stated range.
By their numbers in this assay, from the lowest: compounds 4, 3, 2 and 1 (each within the scatter of the next).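

In this assay, the first measured replacement of the carboxy group at this aromatic carbon gives a 1.6-fold lower number from compound 2 to compound 4 (0.20 log units; within the scatter), so the change stays within the scatter. On the core of compound 2, a compound without carboxy at this carbon therefore still gives a value in the same range, and carboxy is not required for a reading of this size. No measurement shown accounts for the step or gives a cause for it.

Going by these compounds alone, this remains the only pair carrying the change, so its outcome on the cores of compound 1 and compound 3 stays open. Also open, on these data alone, is how a methyl ester, a primary amide or an aminomethyl group would read at this carbon on the core of compound 2.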